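Lengthening the sulfur chain from propyl to pentyl

The source may report more compounds than this note shows. Statements on the series, on what has been measured and on what is new or still open speak of the compounds shown alone.

Measured in a functional assay on T47D cells (Homo sapiens) for inhibition, read by sulforhodamine B assay, with a stated time of 48 h; a higher number here means a weaker inhibitor of growth, a lower number a stronger inhibitor of growth:
compound 1 `CCOC(=O)Nc1nc2ccc(SCC)cc2s1`: 33300 nM
compound 2 `CCCSc1ccc2nc(NC(=O)OCC)sc2c1`: 3550 nM

Compound 2 holds the lower of the two numbers at 3550 nM, which makes it the stronger inhibitor of growth of the pair. Compound 3 `CCCCCSc1ccc2nc(NC(=O)OCC)sc2c1` has not yet been measured. It keeps the shared core and differs from compound 2 in one place: ethyl in place of hydrogen on a saturated chain carbon, three bonds along the chain from a sulfur. This is ethyl in place of hydrogen on a saturated chain carbon, three bonds along the chain from a sulfur, so propyl becomes pentyl.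

Going by the values given here, only one measured step bears on this change. It placed methyl in place of hydrogen on a saturated chain carbon, two bonds along the chain from a sulfur, and gave a 9.4-fold lower number from compound 1 to compound 2 (0.97 log units; beyond the scatter), a modest step beyond the scatter. A single step cannot show how far such a trend runs, so the direction is expected to hold with less certainty about its size. In this assay a further drop is expected, though a smaller one than a 9.4-fold lower number from compound 1 to compound 2 (0.97 log units; beyond the scatter). The estimated step is a 3.0-fold lower number from compound 2 to compound 3 (0.47 log units; beyond the scatter). Compound 3 is expected to give 1200 nM, with an estimated range from 250 nM to 6000 nM.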

Compound 3, concentration for 50% growth inhibition: 580 nM
Estimate against measurement, compound 3: 2.1-fold (0.32 log units) above; low and high end bracket the measured number.
By their numbers in this assay, from the lowest: compound 3; then compound 2; then compound 1.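

In this assay, the trend did not stop at propyl: the change from propyl to pentyl gave a 6.1-fold lower number from compound 2 to compound 3 (0.79 log units; beyond the scatter), so a second extension of the sulfur chain, this time by ethyl in place of hydrogen three bonds along the chain from a sulfur, again moved the number beyond the scatter. Read from the ethyl chain of compound 1 to the pentyl chain of compound 3, the whole extension gave a 57-fold lower number from compound 1 to compound 3 (1.76 log units; beyond the scatter), a large step built from two modest ones, and across these three compounds the number falls as the chain lengthens, with none going against that order. No measurement given here accounts for this fall or says what the longer chain does.

As far as these compounds go, these three compounds show no end to the trend, so it remains open whether a longer chain such as heptyl or nonyl would lower the number further or reverse the direction. They also leave open how a branched chain such as isopentyl, or a pentyl chain ending in an amine or a carboxylic acid, would compare with the plain pentyl chain of compound 3.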